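Replacing the sulfonamide with methoxymethyl in a diaryl alkyne series

This account rests on a few compounds, and the source may have more. Where it says the series, first, only, none or still open, it means among the compounds named here.

Compounds measured:
compound 1 `CC(C)c1ccc(S(C)(=O)=O)cc1C#Cc1cc(C#N)ccc1OCC(=O)O`: 12 nM
compound 2 `CN(C)S(=O)(=O)c1ccc(F)c(C#Cc2cc(Cl)ccc2OCC(=O)O)c1`: 3.1 nM
compound 3 `O=C(O)COc1cc(F)ccc1C#Cc1ccccc1Cl`: 4780 nM

In an assay on CHO cells for displacement of a labelled ligand from prostaglandin D2 receptor 2 (Homo sapiens), read by scintillation counting (on this read-out lower numbers stand for stronger inhibition and higher numbers for weaker inhibition), compound 2 gives the lowest number of the three, with compound 1 nearest and compound 3 furthest, both gaps beyond the scatter. Compound 4 `COCc1ccc(F)c(C#Cc2cc(Cl)ccc2OCC(=O)O)c1` is not yet measured. It differs from compound 2 by methoxymethyl in place of dimethylsulfamoyl on an aromatic carbon. Among the compounds with values here, no measured pair isolates this change, but compound 3, which carries no such group at all, gives 4780 nM, so a loss of potency beyond the scatter is expected, though smaller than that gap. Compound 4 is estimated at 40 nM, between 8 nM and 300 nM, which would mean an expected step of a 13-fold higher number from compound 2 to compound 4 (1.11 log units; beyond the scatter).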

Compound 4, inhibition constant: 72 nM
Beside the measured number, compound 4's estimate is 1.8-fold (0.26 log units) below it; the range from low to high includes it.
By their numbers in this assay, from the lowest: compound 2; then compound 1; then compound 4; then compound 3.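

In this assay, within the data shown here, the pair gives the first direct reading of this position: on an aromatic carbon para to a fluoro group, methoxymethyl in place of dimethylsulfamoyl produces a 23-fold higher number from compound 2 to compound 4 (1.37 log units; beyond the scatter). Potency at this carbon therefore depends on which group it carries, and methoxymethyl does not stand in for dimethylsulfamoyl without a large loss. Nothing given here accounts for the loss.

Going by these compounds, whether a primary carboxamide or a dimethylamino group at this carbon would keep the number closer to that of compound 2 remains open. So does whether a longer ether chain would behave like methoxymethyl.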